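A few compounds are considered here, and "the series" means these few. Any claim that something is new, unique, unknown or untested is made for them only; others in the source may bear on it.

Measured in a functional assay on A549 cells (Homo sapiens) for cytotoxicity, read by MTT assay; on this read-out higher numbers stand for weaker inhibition and lower numbers for stronger inhibition:
Compound 1 `C=C1C(=O)[C@]23C[C@@]1(Cl)CC[C@H]2[C@@]12C=CC(=O)[C@](C)(C(=O)O1)[C@H]2[C@@H]3C(=O)OC`: 60300 nM
Compound 2 `C=C1C(=O)[C@]23C[C@@]1(O)CC[C@H]2[C@@]12C=CC(=O)[C@](C)(C(=O)O1)[C@H]2[C@@H]3C(=O)OC`: 90900 nM
Compound 3 `C=C1C(=O)[C@]23C[C@@]1(F)CC[C@H]2[C@@]12C=CC(=O)[C@](C)(C(=O)O1)[C@H]2[C@@H]3C(=O)OC`: 38900 nM

Compound 3, at 38900 nM, shares the low end of these numbers with compound 1, and the swap of chloro for fluoro, a 1.6-fold lower number from compound 1 to compound 3 (0.19 log units; within the scatter), cannot separate them. Within the data shown here, the one step that clears the scatter is a 2.3-fold lower number from compound 2 to compound 3 (0.37 log units; beyond the scatter). Compound 4 `C=C1C(=O)[C@]23C[C@@]1(I)CC[C@H]2[C@@]12C=CC(=O)[C@](C)(C(=O)O1)[C@H]2[C@@H]3C(=O)OC` carries iodo in place of fluoro on a saturated ring carbon, (iodo in place of fluoro on a saturated ring carbon). Among the measured compounds shown here, no iodo compound has been measured yet, so the closest guide is chloro-bearing compound 1, with its small step of a 1.6-fold lower number from compound 1 to compound 3 (0.19 log units; within the scatter). Iodo is expected to behave more like chloro than fluoro, giving a slightly higher number. The expected change is a 1.4-fold higher number from compound 3 to compound 4 (0.15 log units; within the scatter), which would stay within the scatter. Compound 4 is estimated at 55000 nM, with a range of 28000 nM to 110000 nM.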

Compound 4, half-maximal inhibitory concentration: 53200 nM
Compound 4: middle estimate off by 1.0-fold (0.01 log units), on the high side, and the stated range covers the measured number.
By their numbers in this assay, from the lowest: compounds 3, 4, 1 and 2 (each within the scatter of the next, the first and the last beyond it).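

Iodo on this saturated ring carbon cannot be told apart from the other two halogens in this assay: there is a 1.4-fold higher number from compound 3 to compound 4 (0.14 log units; within the scatter), and also a 1.1-fold lower number from compound 1 to compound 4 (0.05 log units; within the scatter). Iodo also stays unresolved from hydroxy, with a 1.7-fold lower number from compound 2 to compound 4 (0.23 log units; within the scatter), even though fluoro does clear the scatter against hydroxy. No supporting data are available to explain these numbers. As far as these compounds go, whether an amine, a carboxylic acid or a longer chain at this carbon would move the number well away from this narrow band remains open.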